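Swapping cyclohexyl for cyclobutyl in compound 3

The compounds below may be only part of what the source reports. "The series", "measured", "known", "first", "only" and "open" are said of these compounds alone.

Measured so far in an in vitro ADME assay on S9 fraction from liver (Rattus norvegicus, strain Wistar) for metabolic stability, read by HPLC, tested at 1 uM (a higher number here means that the compound lasts longer, a lower number that the compound disappears faster), for three compounds
- compound 1 `NC(=O)c1cccc(-c2cccc(OC(=O)NCCCCc3ccccc3)c2)c1` gives 0.782 h
- compound 2 `O=C(NCc1cccc2ccccc12)Oc1cccc(-c2ccccc2)c1` gives 0.78 h
- compound 3 `O=C(NC1CCCCC1)Oc1cccc(-c2ccccc2)c1` gives 0.1 h

Compound 3 has the lowest half-life of the three, and compound 1 and compound 2 both lie above it by more than the usual scatter. Going by the values given here, the next compound, compound 4 `O=C(NC1CCC1)Oc1cccc(-c2ccccc2)c1`, keeps the core of compound 3 and has cyclobutyl in place of cyclohexyl on an amide-type nitrogen as its only change. Among the compounds with values here, no measured pair shows this change on its own, so the expectation stays anchored on compound 3 at 0.1 h as the closest measured relative. A small rise is expected in this assay, an estimated 1.5-fold higher number from compound 3 to compound 4 (0.18 log units; within the scatter) that stays within the scatter. The expected half-life of compound 4 is 0.15 h (range 0.05 h to 0.5 h).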

Compound 4, half-life: 0.0417 h
The estimate for compound 4 lay 3.6-fold (0.56 log units) above the measured number; the measured number lies below the stated range.
By their numbers in this assay, from the lowest: compound 4; then compound 3; then compounds 2 and 1 (each within the scatter of the next).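

Cyclobutyl in place of cyclohexyl on an amide-type nitrogen gives a 2.4-fold lower number from compound 3 to compound 4 (0.38 log units; beyond the scatter) in this assay. Going by these compounds alone, this is the first single-change comparison at this position, and it shows that the group on this nitrogen matters and that the smaller ring does not make the compound last longer. Nothing measured here gives a reason for this drop.

One step cannot establish a trend with ring size. Cyclopentyl, an open butyl chain, or a ring carrying an amine on the same nitrogen could still behave differently.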